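Iodo for Chloro on the Core of Compound 2

This account rests on a few compounds, and the source may have more. Where it says the series, first, only, none or still open, it means among the compounds named here.

Compound 2 `O=C(O)/C(S)=C/c1c[nH]c2c(Cl)cccc12` gives 90 nM in an assay on isolated protein for inhibition of Calpain-1 catalytic subunit (Sus scrofa) (a lower number here means a stronger inhibitor, a higher number a weaker inhibitor), the lowest of the two numbers recorded so far. Among the compounds with values here, compound 1 `O=C(O)/C(S)=C/c1ccc(I)cc1` gives 5200 nM in this assay; the two values stand far apart, but no single-point step connects them, so only the two numbers themselves can be read. Compound 3 `O=C(O)/C(S)=C/c1c[nH]c2c(I)cccc12` is next and has not yet been measured in this assay. It differs from compound 2 in one place: iodo in place of chloro on an aromatic carbon. Compound 1 also carries iodo, yet on a different core, so it offers no guide to this exchange on the core of compound 2. With nothing to anchor the step, the expectation for a 1.1-fold lower number from compound 2 to compound 3 (0.05 log units; within the scatter) is a change no larger than the usual scatter, in either direction. Compound 3 is therefore estimated at 80 nM in this assay, expected to fall between 30 nM and 250 nM.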

Compound 3, half-maximal inhibitory concentration: 220 nM
Beside the measured number, compound 3's estimate is 2.8-fold (0.44 log units) below it; the measured number falls inside the stated range.
By their numbers in this assay, from the lowest: compound 2; then compound 3; then compound 1.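

Within the data shown here, exchanging chloro for iodo on the core of compound 2 gives the first single-point step in this assay (a 2.4-fold higher number from compound 2 to compound 3 (0.39 log units; beyond the scatter)). The step is modest but beyond the usual scatter, so this aromatic carbon does distinguish between the two groups, and iodo is accepted there with only a limited loss of inhibition. No measurement in hand accounts for the difference.

Among these compounds, two groups at one position define only a single comparison, so they establish no trend. Going by these compounds, whether fluoro, bromo, methyl or methoxy on this carbon would give a number closer to that of compound 2 or compound 3 remains open, as does whether an amine there would be accepted at all.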